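Swapping the pyrazole amide for an imidazole amide

The source may report more compounds than this note shows. Statements on the series, on what has been measured and on what is new or still open speak of the compounds shown alone.

The compounds measured so far in an ADME assay on cells (Hepatocyte, Rattus norvegicus) for metabolic stability (on this read-out lower numbers stand for slow clearance and higher numbers for fast clearance), are:
compound 1 `Cc1ccc2[nH]c(C(=O)N[C@H]3CN(S(=O)(=O)c4ccccc4)C[C@@H]3C(=O)N[C@H]3CCCNC3)cc2c1`, which gives 7 uL/min;
compound 2 `Cc1csc(C(=O)N[C@H]2CN(S(=O)(=O)c3ccccc3)C[C@@H]2C(=O)N[C@H]2CCCNC2)n1`, for which the assay reports only the limit < 1 uL/min;
compound 3 `O=C(N[C@H]1CN(S(=O)(=O)c2ccccc2)C[C@@H]1C(=O)N[C@H]1CCCNC1)c1cc(C2CC2)n[nH]1`, for which the assay again reports only the limit < 1 uL/min.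

Compound 3 thus stands at the floor of the numbers shown, where (the limit of < 1 uL/min in this assay, at which 2 of the 3 values shown sit). The change to compound 4 `O=C(N[C@H]1CN(S(=O)(=O)c2ccccc2)C[C@@H]1C(=O)N[C@H]1CCCNC1)c1cn(C2CC2)cn1` is 1-cyclopropyl-1H-imidazol-4-yl in place of 3-cyclopropyl-1H-pyrazol-5-yl on a carbonyl carbon. For the measured compounds named here, no measured step touches this pair of groups; the steps of an at least 7.0-fold lower number from compound 1 to compound 3 (0.84 log units; beyond the scatter) and an at least 7.0-fold lower number from compound 1 to compound 2 (0.84 log units; beyond the scatter) only show that both five-membered amides sit far from the indole of compound 1, and the step that the two limits leave unreadable from compound 2 to compound 3 cannot be read. In this assay the estimate for compound 4 is therefore 1.5 uL/min, between 0.5 uL/min and 5 uL/min, a step of an at least 1.5-fold higher number from compound 3 to compound 4 (0.17 log units; that floor lies within the scatter) expected to stay near the limit.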

Compound 4, intrinsic clearance in a liver preparation (reported as CLH), per the amount of preparation that the assay uses in the Hepatocyte assay: < 1 uL/min
Compound 4: a limit, no number; the forecaster's own chance of this, stated with the estimate: 40%; middle value at least 1.5-fold (0.17 log units) from the limit.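

Moving from 3-cyclopropyl-1H-pyrazol-5-yl to 1-cyclopropyl-1H-imidazol-4-yl leaves compound 4 at the limit of the Hepatocyte assay, so the steps among compound 2, compound 3 and compound 4 cannot be read, and only the indole stays apart (an at least 7.0-fold lower number from compound 1 to compound 4 (0.84 log units; beyond the scatter)). In a physicochemical assay for lipophilicity, measured as octanol-water partition, at pH 7.4 (a lower number here means a more polar compound, a higher number a more lipophilic compound), compound 3 gives 0.2 and compound 4 gives -0.7 (a number 0.90 log units lower from compound 3 to compound 4 (beyond the scatter)), so these same atoms, joined differently, do separate on this measure.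

Going by these compounds, how far compound 2, compound 3 and compound 4 lie under the limit stays open. So does whether an amine or a carboxylic acid in place of cyclopropyl would keep compound 4 at that limit.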